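A few compounds are considered here, and "the series" means these few. Any claim that something is new, unique, unknown or untested is made for them only; others in the source may bear on it.

Compound 1 `CC/C=C\C(=O)Nc1cc(Nc2nccc(-c3cn(C)c4ccc(F)cc34)n2)c(OC)cc1N(C)CCN(C)C` carries an open-chain unsaturated amide on its core. In a functional assay on A549 cells (Homo sapiens) for antiproliferative activity, read by MTT assay, with a stated time of 72 h (on this read-out lower numbers stand for stronger inhibition and higher numbers for weaker inhibition), compound 1 gives 3600 nM. Compound 2 `CCC/C=C\C(=O)Nc1cc(Nc2nccc(-c3cn(C)c4ccc(F)cc34)n2)c(OC)cc1N(C)CCN(C)C` differs from it only by methyl in place of hydrogen on a saturated chain carbon, two bonds along the chain from a double-bonded chain carbon. In this assay compound 2 gives 1030 nM, which is a 3.5-fold lower number from compound 1 to compound 2 (0.54 log units; beyond the scatter). Compound 3 `CC/C=C\C(=O)Nc1cc(Nc2ncc(C#N)c(-c3cn(C)c4ccc(F)cc34)n2)c(OC)cc1N(C)CCN(C)C` has a different core; the difference between the two cores is cyano in place of hydrogen on an aromatic carbon. In this assay compound 3 gives 4730 nM, which is a 1.3-fold higher number from compound 1 to compound 3 (0.12 log units; within the scatter), so compound 3 and compound 1 cannot be told apart on this read-out.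

Compound 4 `COc1cc(N(C)CCN(C)C)c(NC(=O)/C=C\C(C)C)cc1Nc1ncc(C#N)c(-c2cn(C)c3ccc(F)cc23)n1` has not yet been measured. It differs from compound 3 by methyl in place of hydrogen on a saturated chain carbon bound to a double-bonded chain carbon and a saturated chain carbon. For the measured compounds named here, this is the same kind of change as the one from compound 1 to compound 2, but not the same: in compound 2 the methyl sits on a saturated chain carbon, two bonds along the chain from a double-bonded chain carbon, whereas in compound 4 it sits on a saturated chain carbon bound to a double-bonded chain carbon and a saturated chain carbon. Going by the values given here, only one example of this kind of change has been measured, so the expectation is uncertain. For compound 4 the expected step is a 1.7-fold lower number from compound 3 to compound 4 (0.23 log units; within the scatter), a smaller gain than the earlier one, because the same kind of change gave a 3.5-fold lower number from compound 1 to compound 2 (0.54 log units; beyond the scatter) while the place of the added methyl is different here. In this assay compound 4 is estimated to give 2800 nM, with a likely range from 1200 nM to 6500 nM.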

Compound 4, half-maximal inhibitory concentration: 185 nM
The estimate for compound 4 lay 15-fold (1.18 log units) above the measured number; the whole stated range lies above it.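

In this assay, for the compounds shown here, the change from ethyl to isopropyl on the unsaturated amide gives a 26-fold lower number from compound 3 to compound 4 (1.41 log units; beyond the scatter), which turns the weakest of the first three numbers into the lowest number so far. A methyl added to the chain lowers the number in both measured pairs, but the size of the gain does not carry over from one pair to the other: the same change on two cores in this assay, a 3.5-fold lower number (0.54 log units; beyond the scatter) from compound 1 to compound 2 and a 26-fold lower number (1.41 log units; beyond the scatter) from compound 3 to compound 4, 7.3-fold (0.86 log units) apart, beyond the scatter of two such steps The two steps differ in the core and also in the place of the added methyl, so these results cannot show whether the nitrile on the core, the branched shape of the chain, or both together account for the larger gain, and two pairs make no general rule.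

As far as these compounds go, the decisive comparisons remain open: how the isopropyl chain of compound 4 behaves on the core of compound 1, and how the longer straight chain of compound 2 behaves on the nitrile-bearing core of compound 3. From the compounds shown here alone, it also remains open whether the gain continues with a larger group in place of isopropyl, such as tert-butyl or cyclohexyl, or stops there.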